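The compounds below may be only part of what the source reports. "The series", "measured", "known", "first", "only" and "open" are said of these compounds alone.

Measured in a functional assay on prostate cells (Homo sapiens) for antiproliferative activity; a higher number here means a weaker inhibitor of growth, a lower number a stronger inhibitor of growth: compound 1 `Cc1cn2c(/C=N/NC(=N)N)c(-c3ccncc3)nc2s1` gives 32400 nM; compound 2 `N=C(N)N/N=C/c1c(-c2ccncc2)nc2sc(Cl)cn12` gives 33100 nM.

Compound 1 and compound 2 cannot be told apart on these numbers, since the step of a 1.0-fold higher number from compound 1 to compound 2 (0.01 log units; within the scatter) lies within the scatter. Compound 3 `Cc1cn2c(/C=N/NC(=N)N)c(-c3ccccn3)nc2s1` is not yet measured. It differs from compound 1 in one place: pyridin-2-yl in place of pyridin-4-yl on an aromatic carbon. Among the compounds with values here, the only measured step exchanges chloro for methyl and does not touch the pyridyl group, so there is no measured step that bears on this change, and the data give no direction for it. With nothing to build on, compound 3 is expected to land close to compound 1, with a wide range on either side; the expected step is a 1.0-fold lower number from compound 1 to compound 3 (0.01 log units; within the scatter). The estimate for compound 3 in this assay is therefore 32000 nM, with a range from 8000 nM to 130000 nM.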

Compound 3, concentration for total growth inhibition: 39800 nM
Compound 3: middle estimate off by 1.2-fold (0.09 log units), on the low side; the range from low to high includes it.
By their numbers in this assay, from the lowest: compounds 1, 2 and 3 (each within the scatter of the next).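

Within the data shown here, this is the first measured change at this position, the aromatic carbon next to the ring nitrogen of the shared core. In this assay, pyridin-2-yl in place of pyridin-4-yl uses the same atoms, joined differently, and the step (a 1.2-fold higher number from compound 1 to compound 3 (0.09 log units; within the scatter)) does not separate the two compounds, so the place of the pyridine nitrogen makes no readable difference here. Nothing available explains why the two compounds read alike.

Still open, as far as these compounds go, is whether a group of another kind on this carbon, such as a plain phenyl ring, a morpholine or an amine, would move the number beyond the scatter. Also open, from the compounds shown here alone, is whether pyridin-2-yl would read the same with chloro in place of the methyl on the core.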